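Swapping a whole ring group on the shared core

This account rests on a few compounds, and the source may have more. Where it says the series, first, only, none or still open, it means among the compounds named here.

In an ADME assay on microsomes from liver (Homo sapiens) for metabolic stability, with a stated time of 10 min, tested at 0.5 uM (a lower number here means that less of the compound is left, a higher number that more of the compound is left), compound 1 `CCc1noc(C)c1[C@@H]1C[C@@](C)(c2ccc(F)cc2F)N=C(N)S1` gives 21%. Compound 2 `Cc1onc(-c2ccccc2)c1[C@@H]1C[C@@](C)(c2ccc(F)cc2F)N=C(N)S1` gives 38%, and compound 3 `Cc1onc(-c2cccnc2)c1[C@@H]1C[C@@](C)(c2ccc(F)cc2F)N=C(N)S1` gives 17%. Compound 1 thus sits level with compound 3 within the scatter, while compound 2 stands clear of both.

Compound 4 `C[C@@]1(c2ccc(F)cc2F)C[C@@H](c2cncnc2)SC(N)=N1` has not been measured yet. Its change from compound 1 is larger than any seen so far: pyrimidin-5-yl in place of 3-ethyl-5-methyl-1,2-oxazol-4-yl on a saturated ring carbon. The entire 3-ethyl-5-methyl-1,2-oxazol-4-yl group leaves the saturated ring carbon, and pyrimidin-5-yl takes its place.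

The measured steps are only indirect guides, since each swaps a single group on an aromatic carbon and keeps the rest. Phenyl in place of ethyl gave a number 17 percentage points higher from compound 1 to compound 2 (beyond the scatter), and pyridin-3-yl in place of ethyl gave a number 4 percentage points lower from compound 1 to compound 3 (within the scatter). Pyridin-3-yl in place of phenyl gave a number 21 percentage points lower from compound 2 to compound 3 (beyond the scatter). Among the measured compounds shown here, neither step away from ethyl went clearly downward, so only a slight upward lean can be drawn from them, and no measured compound carries pyrimidin-5-yl.

The expected step is a number 9 percentage points higher from compound 1 to compound 4 (within the scatter), a small one in this assay and held with little confidence. For compound 4 the estimated value is 30%, with an expected range from 10% to 60%.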

Compound 4, percent of the compound remaining: 90%
Beside the measured number, compound 4's estimate is 60 percentage points below it, outside the stated range (above it).
By their numbers in this assay, from the lowest: compounds 3 and 1 (each within the scatter of the next); then compound 2; then compound 4.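

In this assay, among the compounds shown here, replacing the whole group on the saturated ring carbon next to the ring sulfur gives a number 69 percentage points higher from compound 1 to compound 4 (beyond the scatter), a far larger step than a number 17 percentage points higher from compound 1 to compound 2 (beyond the scatter), the biggest rise among the earlier compounds, where only a group on the aromatic carbon changed. This position therefore matters much more for the amount of compound left than the earlier swaps could show, since all of those compounds kept a five-membered aromatic ring here. The counts give no simple account of the difference: both groups have 0 hydrogen-bond donors, 2 hydrogen-bond acceptors and no net charge, differing in ring size and in having 8 heavy atoms against 6, and no measurement here explains why the compound survives so much better.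

As far as these compounds go, the step changes the ring and removes the ethyl and methyl groups together, so it remains open whether the high number belongs to pyrimidin-5-yl itself or would also come with any smaller group at this carbon. A bare 1,2-oxazol-4-yl group or a saturated cyclohexyl ring in the same place would help separate these possibilities.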